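A few compounds are considered here, and "the series" means these few. Any claim that something is new, unique, unknown or untested is made for them only; others in the source may bear on it.

Going by the values given here, in a functional assay on QGY-7703 cells (Homo sapiens) for cytotoxicity, read by MTT assay, with a stated time of 24 h (a lower number here means a stronger inhibitor, a higher number a weaker inhibitor), compound 3 (`COc1cc(/C=C2\CN(S(=O)(=O)c3ccc(NC(C)=O)cc3)C/C(=C\c3ccccc3F)C2=O)cc(OC)c1OC`) gives 2680 nM, the lowest of the three numbers so far, though not clearly separated from all of them. Compound 1 (`COc1cc(/C=C2\CN(S(=O)(=O)c3ccc(F)cc3)C/C(=C\c3cccc([N+](=O)[O-])c3)C2=O)cc(OC)c1OC`) gives 3270 nM, which lies within the usual scatter of compound 3, so these two cannot be told apart. Compound 2 (`CC(=O)Nc1ccc(S(=O)(=O)N2C/C(=C\c3cccc([N+](=O)[O-])c3)C(=O)/C(=C/c3ccccc3F)C2)cc1`) gives 7850 nM, clearly higher. Among the compounds with values here, the only measured single-place change is a 2.9-fold lower number from compound 2 to compound 3 (0.47 log units; beyond the scatter), a modest step that came with 3,4,5-trimethoxyphenyl in place of 3-nitrophenyl.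

Compound 4 (`COc1cc(/C=C2\CN(S(=O)(=O)c3ccc(NC(C)=O)cc3)C/C(=C\c3cccc([N+](=O)[O-])c3)C2=O)cc(OC)c1OC`) keeps that 3,4,5-trimethoxyphenyl and changes the other group on a double-bonded chain carbon: 3-nitrophenyl in place of 2-fluorophenyl on a double-bonded chain carbon bound to a double-bonded ring carbon. The measured step concerns a different group, so it bears on this change only indirectly. The closer guide is compound 1 at 3270 nM, which carries both 3-nitrophenyl and 3,4,5-trimethoxyphenyl, although it differs from compound 4 elsewhere in the structure. Its number sits close to that of compound 3, so no change beyond the scatter is expected in this assay. The estimated step is a 1.2-fold higher number from compound 3 to compound 4 (0.06 log units; within the scatter). For compound 4 the expected value is 3100 nM, with an estimated range from 1500 nM to 6500 nM.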

Compound 4, half-maximal inhibitory concentration: 2550 nM
The estimate for compound 4 lay 1.2-fold (0.08 log units) above the measured number; the range from low to high includes it.
By their numbers in this assay, from the lowest: compounds 4, 3 and 1 (each within the scatter of the next); then compound 2.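

In this assay the group on a double-bonded chain carbon bound to a double-bonded ring carbon can change from 2-fluorophenyl to 3-nitrophenyl with no readable effect while 3,4,5-trimethoxyphenyl stays in the molecule: the result is a 1.1-fold lower number from compound 3 to compound 4 (0.02 log units; within the scatter) and no real difference can be claimed. Compound 2 carries both of those groups and no 3,4,5-trimethoxyphenyl, and putting that group in place of 2-fluorophenyl gives a 3.1-fold lower number from compound 2 to compound 4 (0.49 log units; beyond the scatter) which joins the earlier 2.9-fold lower number from compound 2 to compound 3 (0.47 log units; beyond the scatter) and shows that the step beyond the scatter appears whichever of the two groups is replaced. Acetamido in place of fluoro on an aromatic carbon gives a 1.3-fold lower number from compound 1 to compound 4 (0.11 log units; within the scatter) so this change also shows no readable difference among these compounds.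

Nothing measured here explains why the compounds with 3,4,5-trimethoxyphenyl have the lower numbers. Still open, going by these compounds, is whether an amine or a carboxylic acid on that aromatic carbon would move the number beyond the scatter, and whether 3,4,5-trimethoxyphenyl on both double-bonded chain carbons would lower it further.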